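Enantiomer of compound 2 in the orexin series

The source may report more compounds than this note shows. Statements on the series, on what has been measured and on what is new or still open speak of the compounds shown alone.

Two compounds have numbers in an assay on isolated protein for binding affinity to Orexin receptor type 2 (Homo sapiens); on this read-out higher numbers stand for weaker inhibition and lower numbers for stronger inhibition. Compound 1, `O=C(c1cc(Cl)ccc1-n1nccn1)N1C[C@@H]2C[C@H](C1)N(c1ncc3cc(F)ccc3n1)C2`, gives 0.6 nM. Compound 2, `Cc1ccc(-n2nccn2)c(C(=O)N2C[C@H]3CC[C@@H]2CCN3c2ncc3ccc(F)cc3n2)c1`, gives 2.2 nM; of the two numbers this is the higher one, and the gap to compound 1 lies beyond the scatter. Compound 1 and compound 2 differ in several places at once, so no single step can be read between them.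

Compound 3, `Cc1ccc(-n2nccn2)c(C(=O)N2C[C@@H]3CC[C@H]2CCN3c2ncc3ccc(F)cc3n2)c1`, is the next compound. The change from compound 2 is the two compounds have the same atoms and bonds and differ only in configuration as drawn: 2 of 2 stereo elements differ (all stereocentres are inverted: mirror images); a stereocentre at a saturated ring carbon is drawn R in compound 2 and S in compound 3; a stereocentre at a saturated ring carbon is drawn R in compound 2 and S in compound 3. Nothing leaves and nothing enters.

Among the compounds with values here, no step between measured compounds covers a change of this kind, so direction and size rest on expectation alone. For a mirror-image pair the working expectation is that one antipode carries most of the affinity, and with no second number for this pair the size is open. Compound 3 is expected to give a weaker result, estimated at 50 nM, with a range from 3 nM to 1000 nM. The step that this estimate means, from compound 2 to compound 3, is a 23-fold higher number from compound 2 to compound 3 (1.36 log units; beyond the scatter).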

Compound 3, inhibition constant: 14 nM
Compound 3: middle estimate off by 3.6-fold (0.55 log units), on the high side, within the range that was stated.
By their numbers in this assay, from the lowest: compound 1; then compound 2; then compound 3.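

In this assay, within the data shown here, inverting both stereocentres gives a 6.4-fold higher number from compound 2 to compound 3 (0.80 log units; beyond the scatter), the first step that can be read, since compound 1 and compound 2 differ in several places at once. The gap can be tied to configuration alone: the fact that compounds 2 and 3 differ only in the configuration as drawn. Of this mirror-image pair, compound 2 is the antipode with the stronger inhibition, yet the other antipode keeps measurable affinity, with compound 3 at 14 nM, so on this pair the configuration tunes the number rather than abolishing binding.

From the compounds shown here alone, whether the mirror image of compound 1 would show a gap of similar size remains open, so this single pair cannot be extended into a rule for the series. Also open, going by these compounds, is whether the same order between antipodes holds when a methoxy group replaces the methyl group of compound 2 and compound 3.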